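Ether to Thioether on a Shared Core

This account rests on a few compounds, and the source may have more. Where it says the series, first, only, none or still open, it means among the compounds named here.

Going by the values given here, compound 1 `Nc1cc(N)c2nc(-c3ccccc3)c(Oc3ccc(Cl)c(Cl)c3)nc2c1` is the one compound with an actual number in a functional assay on SW-620 cells (Homo sapiens) for inhibition, read by sulforhodamine B assay, with a stated time of 48 h (a higher number here means that more compound is tolerated, a lower number that less compound is tolerated), where compound 1 gives 91200 nM. Compound 2 `CCOC(=O)[C@H](CCC(=O)O)NC(=O)c1ccc(Oc2nc3cc(N)cc(N)c3nc2-c2ccccc2)cc1` is the other compound run in this assay; in this assay compound 2 reports only < 100000 nM, which is a limit of the measurement and not a number. For compound 2 this is the limit of < 100000 nM in this assay, at which 1 of the 2 values shown sits. Among the compounds with values here, with a single number available, no step between measured compounds exists to show how large a change at this position tends to be. Compound 3 `Nc1cc(N)c2nc(-c3ccccc3)c(Sc3ccc(Cl)c(Cl)c3)nc2c1` differs from compound 1 in one place: (3,4-dichlorophenyl)sulfanyl in place of 3,4-dichlorophenoxy on an aromatic carbon. On this footing, a step in this assay of no more than the usual scatter is expected, in no settled direction. Compound 3 is therefore expected to give 80000 nM, between 30000 nM and 200000 nM. That amounts to an expected step of a 1.1-fold lower number from compound 1 to compound 3 (0.06 log units; within the scatter).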

Compound 3, concentration lethal to 50% of the cells: < 100000 nM
Compound 3 was reported as a limit (the forecaster's own chance of this, stated with the estimate: 30%); the middle value does not contradict the limit.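

In this assay compound 3 gives < 100000 nM, which is a limit and not a number, so no step from compound 1 to compound 3 can be read: the limit of < 100000 nM in this assay, at which 2 of the 3 values shown sit.

The compounds shown leave open whether (3,4-dichlorophenyl)sulfanyl in place of 3,4-dichlorophenoxy changes the read-out at all, and in which direction.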